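This account rests on a few compounds, and the source may have more. Where it says the series, first, only, none or still open, it means among the compounds named here.

Working notes on the shared core. In an assay (strain Wistar) for inhibition of Hormone-sensitive lipase (Rattus norvegicus), read by spectrophotometry (on this read-out higher numbers stand for weaker inhibition and lower numbers for stronger inhibition), compound 1 `Cc1c(C(C)C)c(=O)on1C(=O)N1CCCCC1` gives 2 nM, and compound 3 `Cc1c(C(C)C)c(=O)on1C(=O)N1CCCC1` gives 15 nM, the higher of the two numbers recorded; the step of a 7.5-fold higher number from compound 1 to compound 3 (0.88 log units; beyond the scatter) is modest. Compound 2 `Cc1c(C(C)C)c(=O)on1C(=O)N(C)CC(N)=O` reaches only the limit > 1000 nM in this assay, (the limit of > 1000 nM in this assay, at which 1 of the 3 values shown sits). Compound 4 `Cc1c(C(C)C)c(=O)on1C(=O)N1CC=CC1` differs from compound 3 by a group of 5 heavy atoms (4 carbon, 1 nitrogen; one five-membered non-aromatic ring with 1 hetero atom) in place of a group of 5 heavy atoms (4 carbon, 1 nitrogen; one five-membered non-aromatic ring with 1 hetero atom), on a carbonyl carbon, so the five-membered ring is kept. The measured steps that bear on this are a 7.5-fold higher number from compound 1 to compound 3 (0.88 log units; beyond the scatter), a change of ring size, and an at least 500-fold higher number from compound 1 to compound 2 (2.69 log units; beyond the scatter), where the ring is replaced by an open chain; the change to compound 4 is smaller than either. Compound 4 is therefore expected to show no change at the digits printed from compound 3 to compound 4 (within the scatter), not beyond the scatter. Compound 4 is estimated at 15 nM, between 5 nM and 45 nM.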

Compound 4, half-maximal inhibitory concentration: 72 nM
Compound 4: the middle estimate sits 4.8-fold (0.68 log units) below what was measured; the measured number lies above the stated range.
By their numbers in this assay, from the lowest: compound 1; then compound 3; then compound 4. At a limit, above all of these: compound 2.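

In this assay, a double bond in the five-membered ring changes the reading even though the ring size is kept (a 4.8-fold higher number from compound 3 to compound 4 (0.68 log units; beyond the scatter)), and it widens the distance from the piperidin-1-yl group of compound 1 (a 36-fold higher number from compound 1 to compound 4 (1.56 log units; beyond the scatter)). The ring bearing the double bond still reads well below the open chain (an at least 13-fold lower number from compound 2 to compound 4 (1.14 log units; beyond the scatter)). Compound 2 stands only at a limit of the assay: (the limit of > 1000 nM in this assay, at which 1 of the 4 values shown sits).

From the compounds shown here alone, whether a double bond in the six-membered ring of compound 1 would cost as much remains open. So does the reading of a morpholine or azepane ring on this carbonyl carbon.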